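This account rests on a few compounds, and the source may have more. Where it says the series, first, only, none or still open, it means among the compounds named here.

Three esters sharing one core have been measured. Compound 1 `CC/C=C\C[C@H]1C(=O)C=C[C@H]1CC(=O)OCc1ccccc1` gives 20000 nM in a functional assay on RAW264.7 cells (Mus musculus) for inhibition, read by ELISA, with a stated time of 24 h; a higher number here means that more compound is needed for the effect, a lower number that less compound is needed. Compound 2 `CC/C=C\C[C@H]1C(=O)C=C[C@H]1CC(=O)OCCOC` gives 27000 nM in this assay, and compound 3 `CC/C=C\C[C@H]1C(=O)C=C[C@H]1CC(=O)OC(C)COC` gives 23000 nM there. The three numbers sit close together: a 1.4-fold lower number from compound 2 to compound 1 (0.13 log units; within the scatter), a 1.2-fold higher number from compound 1 to compound 3 (0.06 log units; within the scatter) and a 1.2-fold lower number from compound 2 to compound 3 (0.07 log units; within the scatter).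

Compound 4 `CC/C=C\C[C@H]1C(=O)C=C[C@H]1CC(=O)OC(C)c1ccccc1` has not yet been measured. It differs from compound 3 by phenyl in place of methoxymethyl on a saturated chain carbon bound to an oxygen next to a carbonyl group and a saturated chain carbon. The same kind of change separates compound 2 from compound 1, where it reads phenyl in place of methoxymethyl on a saturated chain carbon bound to an oxygen next to a carbonyl group and made the step of a 1.4-fold lower number from compound 2 to compound 1 (0.13 log units; within the scatter). The two cases are not identical: in compound 3 the carbon that carries the change is also bound to a saturated chain carbon, and the cores of compound 2 and compound 3 differ by methyl in place of hydrogen on a saturated chain carbon bound to an oxygen next to a carbonyl group and a saturated chain carbon.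

Because the earlier step of a 1.4-fold lower number from compound 2 to compound 1 (0.13 log units; within the scatter) stayed within the scatter, the step from compound 3 to compound 4 is expected to be of similar size, a 1.3-fold lower number from compound 3 to compound 4 (0.11 log units; within the scatter). Compound 4 is therefore estimated at 18000 nM, with a range from 9000 nM to 36000 nM.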

Compound 4, half-maximal effective concentration: 18000 nM
Beside the measured number, compound 4's estimate shows no gap at the digits printed; low and high end bracket the measured number.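

In this assay, phenyl in place of methoxymethyl gives a 1.3-fold lower number from compound 3 to compound 4 (0.11 log units; within the scatter), and this step agrees with the one seen on the core without the added methyl: the same change on two cores in this assay, a 1.4-fold lower number (0.13 log units; within the scatter) from compound 2 to compound 1 and a 1.3-fold lower number (0.11 log units; within the scatter) from compound 3 to compound 4, 1.1-fold (0.02 log units) apart, within the scatter of two such steps. Methyl in place of hydrogen gives a 1.1-fold lower number from compound 1 to compound 4 (0.05 log units; within the scatter), and this step likewise agrees with its earlier counterpart: the same change on two cores in this assay, a 1.2-fold lower number (0.07 log units; within the scatter) from compound 2 to compound 3 and a 1.1-fold lower number (0.05 log units; within the scatter) from compound 1 to compound 4, 1.1-fold (0.02 log units) apart, within the scatter of two such steps. All of these steps lie within the scatter, which means that neither change has a measurable effect on either core; they do not show that a step of real size would carry from one core to another in the same way, and none of the compounds tests that.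

The compounds shown leave open whether a carboxylic acid or an amide in place of the ester would give a number close to those of the four esters. Also open, from the compounds shown here alone, is what an ethyl group in place of the added methyl, or a chlorine atom on the phenyl, would do.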